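Extending methyl to ethyl on a shared core: cytotoxicity

The compounds below may be only part of what the source reports. "The series", "measured", "known", "first", "only" and "open" are said of these compounds alone.

Compound 1, `O=c1[nH]c(=O)n(COC(CO)CO)cc1[N+](=O)[O-]`: in a functional assay on HepG2 cells (Homo sapiens) for cytotoxicity (a lower number here means that less compound is tolerated, a higher number that more compound is tolerated), compound 1 gives > 383000 nM, which is a limit of the assay.
Compound 2, `Nc1cn(COC(CO)CO)c(=O)[nH]c1=O`: compound 2 gives > 432000 nM, a limit of the assay.
Compound 3, `Cc1cn(COC(CO)CO)c(=O)[nH]c1=O`: compound 3 gives > 434000 nM, again a limit of the assay.

Compound 3 therefore stands at a limit, and the two other values shown are limits as well; this is recorded in the limit of > 434000 nM in this assay, at which 1 of the 3 values shown sits, with the limit of > 383000 nM in this assay, at which 1 of the 3 values shown sits, and the limit of > 432000 nM in this assay, at which 1 of the 3 values shown sits, for its neighbours. As a consequence none of the three steps between the measured compounds can be read: a step that the two limits leave unreadable from compound 1 to compound 2, a step that the two limits leave unreadable from compound 1 to compound 3 and a step that the two limits leave unreadable from compound 2 to compound 3 all sit between two limits and give no size.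

Compound 4, `CCc1cn(COC(CO)CO)c(=O)[nH]c1=O`, differs from compound 3 by methyl in place of hydrogen on a saturated chain carbon bound to an aromatic carbon. Within the data shown here, no measured step touches this position, and the steps that do exist are unreadable, so there is nothing to suggest a step beyond the scatter in this assay in either direction. The estimate for compound 4 is accordingly 450000 nM, with a range from 150000 nM to 1500000 nM, most probably reported again only as a limit. The expected step is a step that the limit leaves unreadable from compound 3 to compound 4.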

Compound 4, half-maximal cytotoxic concentration: > 410000 nM
Compound 4: a limit, no number; the forecaster's own chance of this, stated with the estimate: 80%; the middle value lies beyond the limit too.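

In this assay compound 4 gives > 410000 nM, which is a limit of the assay. Its steps from compound 1, compound 2 and compound 3 therefore cannot be read. The compounds shown leave open at what concentration any of the four becomes cytotoxic, and whether changing the group on the shared core alters that concentration at all.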